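Pyridin-2-yl to 1,3-Thiazol-2-yl at a Chain Carbon

The source may report more compounds than this note shows. Statements on the series, on what has been measured and on what is new or still open speak of the compounds shown alone.

Compound 1 `N=C(NCCCc1c[nH]cn1)NC(=O)CC(c1ccccc1)c1ccc(F)cc1`: 55 nM
Compound 2 `N=C(NCCCc1c[nH]cn1)NC(=O)CC(c1ccccc1)c1ccc(F)c(F)c1`: 53.7 nM
Compound 3 `N=C(NCCCc1c[nH]cn1)NC(=O)CC(c1ccccc1)c1ccccn1`: 51.3 nM

All three were tested in a functional assay on cardiac atrium for agonist activity at histamine H2 receptor (Cavia porcellus); on this read-out lower numbers stand for an effect already at smaller amounts and higher numbers for an effect only at larger amounts of compound. Compound 3 stands at the low end of these three numbers, but compound 2 and compound 1 both lie within the scatter of it, so the three cannot be told apart. Compound 4 `N=C(NCCCc1c[nH]cn1)NC(=O)CC(c1ccccc1)c1nccs1` differs from compound 3 in one place: 1,3-thiazol-2-yl in place of pyridin-2-yl on a saturated chain carbon bound to an aromatic carbon and a saturated chain carbon. Two measured steps exchange the group at this same place: a 1.1-fold lower number from compound 1 to compound 3 (0.03 log units; within the scatter) and a 1.0-fold lower number from compound 2 to compound 3 (0.02 log units; within the scatter). Both stayed within the scatter. No step beyond the scatter is therefore expected for this exchange either. The estimated step is a 1.1-fold higher number from compound 3 to compound 4 (0.03 log units; within the scatter). Compound 4 is expected to give about 55 nM in this assay, with a range from 25 nM to 120 nM.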

Compound 4, half-maximal effective concentration: 38 nM
The estimate for compound 4 lay 1.4-fold (0.16 log units) above the measured number; low and high end bracket the measured number.
By their numbers in this assay, from the lowest: compounds 4, 3, 2 and 1 (each within the scatter of the next).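

The earlier compounds shown here carry only six-membered aromatic rings at this place, whereas compound 4 carries a five-membered aromatic ring with a sulfur atom. In this assay this difference in ring cannot be told apart from the usual scatter, with a 1.4-fold lower number from compound 3 to compound 4 (0.13 log units; within the scatter) and a 1.4-fold lower number from compound 2 to compound 4 (0.15 log units; within the scatter) and a 1.4-fold lower number from compound 1 to compound 4 (0.16 log units; within the scatter) as the steps. Nothing available explains why these exchanges leave the number so little changed.

Still open, as far as these compounds go, is whether a non-aromatic group at this place, such as an amine, a carboxylic acid or a cyclohexyl ring, would also stay within the scatter.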